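Swapping 3-Fluorophenyl for a Larger Naphthalen-1-yl Group

The source may report more compounds than this note shows. Statements on the series, on what has been measured and on what is new or still open speak of the compounds shown alone.

Of the compounds shown here, three sharing one core have been measured in a functional assay on GBM3 cells (Homo sapiens) for antiproliferative activity, read by WST assay, with a stated time of 72 h; on this read-out higher numbers stand for weaker inhibition and lower numbers for stronger inhibition. Compound 1 (`O=C(Nc1cccc(Cl)c1)Nc1cc2ncncc2cc1OCc1ccccc1Cl`) gives 2800 nM. Compound 2 (`O=C(Nc1cccc(F)c1)Nc1cc2ncncc2cc1OCc1ccccc1Cl`) gives 2400 nM, and compound 3 (`O=C(Nc1cccc(F)c1)Nc1cc2ncncc2cc1OCc1cccc(Cl)c1`) gives 8300 nM. Compound 2 therefore stands at the low end of these numbers, level with compound 1 within the scatter, while compound 3 lies clearly higher.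

The next compound is compound 4 (`O=C(Nc1cc2ncncc2cc1OCc1ccccc1Cl)Nc1cccc2ccccc12`), which carries naphthalen-1-yl in place of 3-fluorophenyl on an amide-type nitrogen.

Within the data shown here, two measured steps bear on this change. The closer one is a 1.2-fold lower number from compound 1 to compound 2 (0.07 log units; within the scatter). It alters the group on the same amide-type nitrogen, but only by exchanging chloro for fluoro, and it stays within the scatter. The other is a 3.5-fold higher number from compound 2 to compound 3 (0.54 log units; beyond the scatter), a modest step, but it lies in a different part of the molecule. It shows only that this series can respond to a single change. Among the measured compounds shown here, no measured compound carries a second ring on that nitrogen, so the guidance is indirect, and no step beyond the scatter is expected in this assay.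

The expected change is a 1.3-fold higher number from compound 2 to compound 4 (0.10 log units; within the scatter). For compound 4 the estimated value is 3000 nM, with an expected range of 1000 nM to 9000 nM.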

Compound 4, half-maximal inhibitory concentration: 2700 nM
Beside the measured number, compound 4's estimate is 1.1-fold (0.05 log units) above it; the measured number falls inside the stated range.
By their numbers in this assay, from the lowest: compounds 2, 4 and 1 (each within the scatter of the next); then compound 3.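

In this assay, the step from 3-fluorophenyl to naphthalen-1-yl is a 1.1-fold higher number from compound 2 to compound 4 (0.05 log units; within the scatter) and the step from 3-chlorophenyl to naphthalen-1-yl is a 1.0-fold lower number from compound 1 to compound 4 (0.02 log units; within the scatter) so compound 1, compound 2 and compound 4 cannot be told apart. The earlier compounds shown here showed only that one halogen could replace another on this single ring, whereas compound 4 shows that the group on the amide-type nitrogen can take on more heavy atoms, gain a second aromatic ring and carry no halogen at all, while the number stays level. Nothing available explains why the number stays level.

Still open, as far as these compounds go, is whether this tolerance extends to other kinds of group on the same nitrogen, such as a saturated cyclohexyl ring, a pyridin-3-yl ring or a chain ending in an amine, and whether any of them would move the number beyond the scatter. Also open, from the compounds shown here alone, is whether naphthalen-1-yl would give a similar number alongside the 3-chlorophenyl group of compound 3.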